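A few compounds are considered here, and "the series" means these few. Any claim that something is new, unique, unknown or untested is made for them only; others in the source may bear on it.

Measured compounds in a functional assay on CHO cells for positive allosteric modulation of metabotropic glutamate receptor 2 (Homo sapiens), read by scintillation counting and GTPgammaS binding, with a stated time of 30 min; on this read-out lower numbers stand for smaller maximal responses and higher numbers for larger maximal responses:

compound 1, `CCCCn1ccc(-c2ccc(Oc3ccnc(C)c3)cc2)c(C#N)c1=O`, 243%
compound 2, `Cc1cc(Oc2ccc(-c3ccn(CC4CC4)c(=O)c3C#N)cc2)ccn1`, 199%
compound 3, `CCCCn1ccc(-c2ccc(Oc3cccnc3C)c(Cl)c2)c(C#N)c1=O`, 236%

Compound 1 and compound 2 share a core and differ by cyclopropyl in place of propyl on a saturated chain carbon bound to an aromatic nitrogen; this change gave a number 44 percentage points lower from compound 1 to compound 2 (beyond the scatter) in this assay. Compound 3 carries a different core; how the core of compound 3 differs from that of compound 1 is not broken down here. Compound 3 and compound 1 lie within the scatter of each other, while compound 3 sits well above compound 2.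

Compound 4, `Cc1ncccc1Oc1ccc(-c2ccn(CC3CC3)c(=O)c2C#N)cc1Cl`, has not yet been measured in this assay. It differs from compound 3 by cyclopropyl in place of propyl on a saturated chain carbon bound to an aromatic nitrogen, at the same place as the change from compound 1 to compound 2, so this is the same change made on the core of compound 3. Going from compound 3 to compound 4 the step is expected to be about a number 41 percentage points lower from compound 3 to compound 4 (beyond the scatter), because the one measured example of this change, a number 44 percentage points lower from compound 1 to compound 2 (beyond the scatter), was large and well beyond the scatter. Among the measured compounds shown here, with only one prior example and a different core, the range is kept wide. Compound 4 is estimated at 195%, between 160% and 235%.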

Compound 4, largest response reached (Emax), in percent of the reference or control that the assay uses: 180%
Compound 4: middle estimate off by 15 percentage points, on the high side; the measured number falls inside the stated range.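

Cyclopropyl in place of propyl on a saturated chain carbon bound to an aromatic nitrogen gave a number 56 percentage points lower from compound 3 to compound 4 (beyond the scatter) in this assay, so the drop in maximal response seen on the core of compound 1 also appears on the core of compound 3. Set beside the earlier step, the size of the change cannot be told apart between the two cores:

the same change on two cores in this assay, a number 44 percentage points lower (beyond the scatter) from compound 1 to compound 2 and a number 56 percentage points lower (beyond the scatter) from compound 3 to compound 4, 12 percentage points apart, within the scatter of two such steps

This is agreement across two cores only: it does not establish that the step would hold on any further core, and it gives no explanation for the lower response.

The compounds shown leave open how other groups at this place would behave, since only butyl and cyclopropylmethyl appear there, and a longer chain such as hexyl or a chain ending in an amine remains unplaced on either core. Also open, as far as these compounds go, is whether the step survives when the nitrile gives way to a carboxylic acid, as all four compounds keep the nitrile.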